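The source may report more compounds than this note shows. Statements on the series, on what has been measured and on what is new or still open speak of the compounds shown alone.

Working notes on the series. Compound 1 `COC(=O)[C@@]1(C)CCC=C2[C@@H]1CC[C@@H](C)[C@]2(C)Cc1c(C)[nH]c2ccc(F)cc12` and compound 2 `COC(=O)[C@@]1(C)CCC=C2[C@@H]1CC[C@@H](C)[C@]2(C)Cc1c(C)[nH]c2ccc(OC)cc12` share one core; compound 3 `COC(=O)[C@@]1(C)CC[C@@H]2C3=C1CC[C@@H](C)[C@]3(C)C[C@@H]1c3cc(F)ccc3N[C@H]21` and compound 4 `COC(=O)[C@@]1(C)CC[C@@H]2C3=C1CC[C@@H](C)[C@]3(C)C[C@@H]1c3cc(OC)ccc3N[C@H]21` share another. The difference between the two cores is not broken down here.

In a functional assay on HBL-100 cells (Homo sapiens) for inhibition, read by sulforhodamine B assay, with a stated time of 48 h (on this read-out higher numbers stand for weaker inhibition of growth and lower numbers for stronger inhibition of growth), compound 1 gives 14000 nM. In this assay compound 2 gives 16000 nM. The change from compound 1 to compound 2 is methoxy in place of fluoro on an aromatic carbon and it gave a 1.1-fold higher number from compound 1 to compound 2 (0.06 log units; within the scatter).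

In this assay compound 3 gives 18000 nM. Its value and those of compound 1 and compound 2 lie within the scatter of one another, so no order among the three is read from them.

Compound 4 is not yet measured. It differs from compound 3 by methoxy in place of fluoro on an aromatic carbon. This is the same kind of change as that from compound 1 to compound 2, but not the same: in compound 1 the aromatic carbon that carries the group is part of a fused or bridged system of two rings, in compound 3 it is part of a fused or bridged system of five rings.

Within the data shown here, the expectation for compound 4 rests on the one measured instance of this kind of change: the step from compound 1 to compound 2 in this assay was a 1.1-fold higher number from compound 1 to compound 2 (0.06 log units; within the scatter). Carried over to the other core, the estimated step is a 1.1-fold higher number from compound 3 to compound 4 (0.05 log units; within the scatter). Compound 4 is therefore expected to give about 20000 nM in this assay, with the estimate spanning 10000 nM to 40000 nM.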

Compound 4, concentration for 50% growth inhibition: 15000 nM
Estimate against measurement, compound 4: 1.3-fold (0.12 log units) above; measured number inside the range.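

On the second core in this assay, methoxy in place of fluoro on an aromatic carbon gives a 1.2-fold lower number from compound 3 to compound 4 (0.08 log units; within the scatter). Set beside the earlier step, the change shows no readable difference between the two cores: the same change on two cores in this assay, a 1.1-fold higher number (0.06 log units; within the scatter) from compound 1 to compound 2 and a 1.2-fold lower number (0.08 log units; within the scatter) from compound 3 to compound 4, 1.4-fold (0.14 log units) apart, within the scatter of two such steps. Among these compounds, with both steps inside the scatter, this pair shows only that the exchange of these two groups has no readable effect on either core in this assay; it does not show that the two cores respond alike to other changes, and it does not establish a shared direction or size for this one, so two instances make no general rule for the series.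

The compounds shown leave open whether any other group on this aromatic carbon, such as an amine, a carboxylic acid or a longer alkoxy chain, would give a step beyond the scatter on either core, and whether such a step would carry from one core to the other. Also open, on these data alone, is what happens when the methyl ester common to all four compounds gives way to a carboxylic acid or an amide.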